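The source may hold more compounds than are shown below. What is called first, only, known or untested is meant among the compounds shown, and "the series" means these compounds.

Compound 1 `COc1ccc(Nc2nc(N)c(C(=O)c3ccccc3)s2)cc1` gives 730 nM in a functional assay on FM3A cells (Mus musculus) for antiproliferative activity, read by cell counting, with a stated time of 2 days; on this read-out higher numbers stand for weaker inhibition and lower numbers for stronger inhibition. Compound 2 `Nc1nc(Nc2ccc(Cl)cc2)sc1C(=O)c1ccccc1` returns no number in this assay but only a limit, > 10000 nM, which is the limit of > 10000 nM in this assay, at which 1 of the 3 values shown sits. Compound 3 `COc1cc(C(=O)c2sc(Nc3ccc(Cl)cc3)nc2N)cc(OC)c1OC` gives 420 nM in this assay, and the difference between the core of compound 3 and the core of compound 2 is not broken down here. Between compound 2 and compound 1 the change is methoxy in place of chloro on an aromatic carbon, and it produced an at least 13-fold lower number from compound 2 to compound 1 (1.13 log units; beyond the scatter). The same change, (methoxy in place of chloro on an aromatic carbon), leads from compound 3 to compound 4 `COc1ccc(Nc2nc(N)c(C(=O)c3cc(OC)c(OC)c(OC)c3)s2)cc1`, for which this assay has not yet been run. The step is expected to carry over in kind because an at least 13-fold lower number from compound 2 to compound 1 (1.13 log units; beyond the scatter) shows what this exchange did on the shared core, although that earlier step starts from a limit and its full size is not known. Compound 4 is therefore expected to show a 7.0-fold lower number from compound 3 to compound 4 (0.85 log units; beyond the scatter) in this assay. Compound 4 is estimated at 60 nM, with a range of 10 nM to 400 nM.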

Compound 4, half-maximal inhibitory concentration: 2200 nM
Beside the measured number, compound 4's estimate is 37-fold (1.56 log units) below it, outside the stated range (above it).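

In this assay the exchange of chloro for methoxy did not carry over in kind, giving a 5.2-fold higher number from compound 3 to compound 4 (0.72 log units; beyond the scatter), so the two cores moved in opposite directions: the same change on two cores in this assay, an at least 13-fold lower number (1.13 log units; beyond the scatter) from compound 2 to compound 1 and a 5.2-fold higher number (0.72 log units; beyond the scatter) from compound 3 to compound 4, at least 71-fold (1.85 log units) apart, beyond the scatter of two such steps

The earlier of the two steps starts from a limit and not from a number, and its full size stays unknown: the limit of > 10000 nM in this assay, at which 1 of the 4 values shown sits.

These two pairs show that, in this series, the direction of the change on one core cannot be taken as a guide to its direction on the other, but they do not show why the cores part or how the change would behave on any further core.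

The compounds shown leave open what other groups at this place would do on either core, for example a methyl group, a fluoro group or a dimethylamino group in place of chloro or methoxy. Going by these compounds, whether such groups would also part between the two cores remains open as well.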